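Butyl to Fluoro at the Aromatic Carbon: Expecting Compound 4

A few compounds are considered here, and "the series" means these few. Any claim that something is new, unique, unknown or untested is made for them only; others in the source may bear on it.

Of the compounds shown here, three built on one shared core have been measured in an ADME assay on the whole organism with Oryza sativa as the target, tested at 0.1 uM; on this read-out higher numbers stand for a weaker effect at the one concentration tested and lower numbers for a stronger effect. Compound 1 `CC(C)c1ccc(NC(=O)N[C@@H](C)c2ccccc2)cc1` gives 98%, compound 2 `CCCCc1ccc(NC(=O)N[C@H](C)c2ccccc2)cc1` gives 100%, and compound 3 `CCCCc1ccc(NC(=O)N[C@@H](C)c2ccccc2)cc1` gives 98%. Compound 2 carries the highest of the three numbers, yet neither neighbour is separated from it beyond the scatter. The step of a number 2 percentage points lower from compound 2 to compound 3 (within the scatter) is flat, which fits with the fact that compounds 2 and 3 differ only in the configuration as drawn. The step of no change at the digits printed from compound 1 to compound 3 (within the scatter), butyl in place of isopropyl, is flat as well, so exchanging one alkyl for another at this aromatic carbon left the read-out unmoved.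

Compound 4 `C[C@@H](NC(=O)Nc1ccc(F)cc1)c1ccccc1` has not been measured. Against compound 2, (fluoro in place of butyl on an aromatic carbon). Within the data shown here, no measured step exchanges an alkyl chain for a halogen, so the only guide is the flat alkyl-for-alkyl step between compound 1 and compound 3, which argues for little movement, while the drop from four heavy atoms to one heavy atom at that position leaves room for some change.

Compound 4 is therefore expected to give about 96% in this assay, with a range from 85% to 100%. This estimate means an expected step of a number 4 percentage points lower from compound 2 to compound 4 (within the scatter), most likely within the scatter.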

Compound 4, a percentage reported as activity, at one concentration (the size of the read-out at that concentration, not a potency): 98%
The estimate for compound 4 lay 2 percentage points below the measured number; measured number inside the range.
By their numbers in this assay, from the lowest: compounds 1, 3, 4 and 2 (each within the scatter of the next).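

In this assay the exchange of fluoro for butyl on this aromatic carbon, para to a large group, gave a number 2 percentage points lower from compound 2 to compound 4 (within the scatter), so the flat behaviour at this position is no longer confined to swapping one alkyl for another. The earlier compounds shown here had varied only the alkyl chain here, whereas this change removes the chain altogether, replacing 4 heavy atoms, all carbon, with 1 heavy atom of fluorine, and the read-out still stays within the scatter. Nothing on record explains why this position tolerates the change, and the only available observation, on configuration, does not bear on this exchange.

Going by these compounds, whether an amine, a carboxylic acid or a chain longer than butyl on this aromatic carbon would leave this assay equally flat remains open, as does whether a change elsewhere on the shared core would move it at all. Since the read-out comes from one concentration, these compounds also leave open whether the exchange of butyl for fluoro would stay flat at any other concentration.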